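This account rests on a few compounds, and the source may have more. Where it says the series, first, only, none or still open, it means among the compounds named here.

Measured in a functional assay on K562 cells (Homo sapiens) for antiproliferative activity, read by MTT assay, with a stated time of 48 h; on this read-out lower numbers stand for stronger inhibition and higher numbers for weaker inhibition:
- Compound 1 `COc1ccc(-c2ccc3c(c2)C(=O)C(=O)N3c2ccc(OC)cc2)cc1`: > 10000 nM, a limit and not a number
- Compound 2 `COc1ccc(-c2ccc3c(c2)C(=O)C(=O)N3Cc2ccc(C#N)cc2)cc1`: 380 nM
- Compound 3 `COc1ccc(CN2C(=O)C(=O)c3cc(-c4cccc(OC)c4)ccc32)cc1`: 100 nM

Of the two true numbers, compound 3 holds the lower one, so it is the best starting point in this small set. Compound 4 `COc1ccc(CN2C(=O)C(=O)c3cc(-c4ccc(OC(C)C)cc4)ccc32)cc1` carries 4-isopropoxyphenyl in place of 3-methoxyphenyl on an aromatic carbon.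

Going by the values given here, the only measured single-place step, an at least 26-fold lower number from compound 1 to compound 2 (1.42 log units; beyond the scatter), is large, but it lies on an amide-type nitrogen in a ring, so it does not bear directly on this aromatic carbon. Among the compounds with values here, with no measured step at this place, the expected change in this assay is small, estimated as a 1.5-fold higher number from compound 3 to compound 4 (0.18 log units; within the scatter), not beyond the scatter. For compound 4 the estimated value is 150 nM, with an expected range of 40 nM to 600 nM.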

Compound 4, half-maximal inhibitory concentration: 310 nM
Beside the measured number, compound 4's estimate is 2.1-fold (0.32 log units) below it; low and high end bracket the measured number.
By their numbers in this assay, from the lowest: compound 3; then compounds 4 and 2 (each within the scatter of the next). At a limit, above all of these: compound 1.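

In this assay, going by these compounds alone, the group on this aromatic carbon affects the result: 4-isopropoxyphenyl in place of 3-methoxyphenyl gives a 3.1-fold higher number from compound 3 to compound 4 (0.49 log units; beyond the scatter), the first measured step at this place. The position therefore does not accept every aryl group equally. Nothing measured here accounts for the size of this step.

The swap changes both where the ether sits on the ring and which ether it is, so these two changes cannot be separated; a 3-isopropoxyphenyl group would help to do so. On these data alone, how a ring carrying an amine or a carboxylic acid would behave here remains open.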